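Adding a Methoxy Group to Two Related Inhibitors

The compounds below may be only part of what the source reports. "The series", "measured", "known", "first", "only" and "open" are said of these compounds alone.

Measured compounds:
compound 1, `Cn1c(=O)[nH]c2nc(SCC(=O)c3ccccc3)[nH]c2c1=O`, gives 11900 nM
compound 2, `COc1ccc(C(=O)CSc2nc3[nH]c(=O)n(C)c(=O)c3[nH]2)cc1`, gives 6100 nM
compound 3, `Cn1c(=O)[nH]c2nc(SC/C(=N/O)c3ccccc3)[nH]c2c1=O`, gives 5600 nM

All three were tested in a functional assay on A549 cells (Homo sapiens) for inhibition, read by MTT assay, with a stated time of 48 h; on this read-out higher numbers stand for weaker inhibition and lower numbers for stronger inhibition. Compound 2 differs from compound 1 in one place: methoxy in place of hydrogen on an aromatic carbon. That change produced a 2.0-fold lower number from compound 1 to compound 2 (0.29 log units; within the scatter), so the two values cannot be told apart with confidence. Compound 3 carries a different core; how the core of compound 3 differs from that of compound 1 is not broken down here. In this assay compound 3 gives 5600 nM, a number within the scatter of compound 2 but beyond the scatter from compound 1.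

Compound 4, `COc1ccc(/C(CSc2nc3[nH]c(=O)n(C)c(=O)c3[nH]2)=N\O)cc1`, has not yet been measured. It differs from compound 3 in one place: methoxy in place of hydrogen on an aromatic carbon. This is the same change as the one from compound 1 to compound 2, now made on the core of compound 3; among the compounds shown it occurs twice in all. Because the earlier instance gave a 2.0-fold lower number from compound 1 to compound 2 (0.29 log units; within the scatter), a step of about that size is expected here as well, namely a 1.6-fold lower number from compound 3 to compound 4 (0.20 log units; within the scatter). This expectation rests on a single measured pair, so it is held loosely. Compound 4 is therefore estimated to give 3500 nM in this assay, with the estimate spanning from 1800 nM to 7000 nM.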

Compound 4, half-maximal inhibitory concentration: 1500 nM
The estimate for compound 4 lay 2.3-fold (0.37 log units) above the measured number; the whole stated range lies above it.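

Putting methoxy in place of hydrogen on the aromatic ring, which turns phenyl into 4-methoxyphenyl, gave a 3.7-fold lower number from compound 3 to compound 4 (0.57 log units; beyond the scatter) in this assay, a step large enough on its own to stand out from ordinary repeat-to-repeat variation. Set beside the earlier step, it points the same way, and the two sizes cannot be told apart: the same change on two cores in this assay, a 2.0-fold lower number (0.29 log units; within the scatter) from compound 1 to compound 2 and a 3.7-fold lower number (0.57 log units; beyond the scatter) from compound 3 to compound 4, 1.9-fold (0.28 log units) apart, within the scatter of two such steps. This shows that the change lowered the number on both cores shown, though only the step on the core of compound 3 is clear by itself; it does not show that one core responds more strongly than the other, and two pairs cannot establish a rule for cores beyond these.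

Only hydrogen and methoxy appear at this place on the ring, so the compounds shown leave open whether other groups there, such as an amine, a carboxylic acid or a longer chain like ethoxy, would lower the number as well, or raise it. They also leave open whether the same change would behave alike on any further core, since all of this rests on a single cell assay.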